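This account rests on a few compounds, and the source may have more. Where it says the series, first, only, none or still open, it means among the compounds named here.

Working notes on a small set of hydroxamic acids, all carrying the same core as compound 1 `CC(=O)N(O)C(C)c1ccc2oc(-c3ccccc3)cc2c1`. In an assay on RBL cells for inhibition of Polyunsaturated fatty acid 5-lipoxygenase (Rattus norvegicus) (a higher number here means a weaker inhibitor, a lower number a stronger inhibitor), compound 1 gives 490 nM. Among the measured compounds shown here, the only other measured member is compound 2 `COc1cc(-c2cc3cc(C(C)N(O)C(C)=O)ccc3o2)cc(OC)c1OC`, which carries three methoxy groups on the pendant phenyl ring; in this assay compound 2 gives 310 nM. Compound 1 has the higher number of the two, but the gap to compound 2 is within the usual scatter, so the two values are read as equal and the added methoxy groups do not separate the compounds here.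

The next member is compound 3 `CC(c1ccc2oc(-c3ccccc3)cc2c1)N(O)C(=O)c1cccs1`, which keeps the core of compound 1 unchanged and alters only the acyl part of the hydroxamic acid: thiophen-2-yl in place of methyl on a carbonyl carbon. For the measured compounds named here, no step between measured compounds shows a change at this carbonyl carbon, so no measured pair can be drawn on for its size or direction. The step of a 1.3-fold higher number from compound 1 to compound 3 (0.12 log units; within the scatter) is therefore expected to stay within the scatter, leaning if anything toward a slightly higher number. Compound 3 is estimated at 650 nM in this assay, with a range from 200 nM to 2000 nM.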

Compound 3, half-maximal inhibitory concentration: 250 nM
The estimate for compound 3 lay 2.6-fold (0.41 log units) above the measured number; low and high end bracket the measured number.
By their numbers in this assay, from the lowest: compounds 3, 2 and 1 (each within the scatter of the next).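

On the carbonyl carbon of the hydroxamic acid, thiophen-2-yl in place of methyl gives in this assay a 2.0-fold lower number from compound 1 to compound 3 (0.29 log units; within the scatter) and so the two compounds are read as equal. Among the compounds shown here, this is the first measured change at this carbonyl carbon, and it shows that the single carbon of methyl can give way to 5 heavy atoms, including a five-membered aromatic ring with a sulfur atom, without a step beyond the scatter. Nothing in hand speaks to why the number holds through this exchange.

From the compounds shown here alone, with only one replacement at this carbonyl carbon in the set, it remains open whether phenyl, furan-2-yl or a longer chain such as n-butyl would also stay within the scatter of compound 1, and whether a dimethylamino group in the same place would do so. Also open, going by these compounds, is how thiophen-2-yl on the carbonyl carbon would read together with the three methoxy groups of compound 2 on the pendant phenyl ring.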